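Working notes: aryl swaps on the amine nitrogen, one series

This account rests on a few compounds, and the source may have more. Where it says the series, first, only, none or still open, it means among the compounds named here.

compound 1 `Fc1ccc(Nc2nc(-c3cccc(F)c3)nc3ccc(F)cc23)cc1` — in a functional assay on MDA-MB-231 cells (Homo sapiens) for cytotoxicity, read by MTT assay, with a stated time of 48 h (on this read-out lower numbers stand for stronger inhibition and higher numbers for weaker inhibition), compound 1 returns only a limit, > 50000 nM.
compound 2 `Fc1cccc(Nc2nc(-c3cccc(F)c3)nc3ccc(F)cc23)c1` — in this assay compound 2 gives 47600 nM.
compound 3 `Fc1cccc(-c2nc(Nc3ccccc3Br)c3cc(F)ccc3n2)c1` — in this assay compound 3 returns only a limit, > 50000 nM.

For the measured compounds named here, compound 2 is the only member with a numerical value in this assay; the other two sit at a limit, (the limit of > 50000 nM in this assay, at which 2 of the 3 values shown sit). All three differ only in the aryl group on the nitrogen on the aromatic ring. The steps measured there are small or unreadable: an at least 1.0-fold lower number from compound 1 to compound 2 (0.02 log units; that floor lies within the scatter); an at least 1.0-fold higher number from compound 2 to compound 3 (0.02 log units; that floor lies within the scatter); a step that the two limits leave unreadable from compound 1 to compound 3.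

Compound 4 `Cc1ccccc1Nc1nc(-c2cccc(F)c2)nc2ccc(F)cc12` is not yet measured. Against compound 2 the change is 2-methylphenyl in place of 3-fluorophenyl on a nitrogen on an aromatic ring, so again the (3-fluorophenyl)amino group gives way to another arylamino at the same place. Both readable steps at this position stay within the scatter, so no step beyond the scatter is expected in this assay, in either direction, and a limit rather than a number is a real possibility.

Compound 4 is therefore estimated at 50000 nM in this assay, with a range of 25000 nM to 100000 nM. That estimate means an expected 1.1-fold higher number from compound 2 to compound 4 (0.02 log units; within the scatter).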

Compound 4, half-maximal inhibitory concentration: > 50000 nM
Compound 4: no number, only a limit; the forecaster's own chance of this, stated with the estimate: 60%; the middle value lies on the limit itself.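

In this assay, for the compounds shown here, the 2-methylphenyl group is the first aryl group on this nitrogen without a halogen, and compound 4 returns only a limit, > 50000 nM. Exchanging the 3-fluorophenyl group for it gives an at least 1.0-fold higher number from compound 2 to compound 4 (0.02 log units; that floor lies within the scatter), so replacing the fluorine-bearing aryl group with a methyl-bearing one opens no step beyond the scatter. The steps that join compound 4 to compound 1 and to compound 3, including methyl in place of bromo, cannot be read because their values are limits: the limit of > 50000 nM in this assay, at which 3 of the 4 values shown sit.

As far as these compounds go, it remains open whether any group on this nitrogen gives a number well clear of that limit, for example an aryl group carrying a carboxylic acid or an amine, or a longer alkyl chain in place of the aryl group. From the compounds shown here alone, the effect of changes elsewhere on the shared core also remains open.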